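Benzyloxy to methoxy: what to expect for growth inhibition

A few compounds are considered here, and "the series" means these few. Any claim that something is new, unique, unknown or untested is made for them only; others in the source may bear on it.

Measured compounds:
compound 1 `O=c1cc(-c2ccccc2)oc2cc(OCc3ccccc3)c(OCCCCN3CCCCC3)c(O)c12`: 2400 nM
compound 2 `O=c1cc(-c2ccccc2)oc2cc(OCc3ccccc3)c(OCCCN3CCCC3)c(O)c12`: 4200 nM
compound 3 `CN1CCN(CCCCOc2c(O)cc3oc(-c4ccccc4)cc(=O)c3c2O)CC1`: 93700 nM

In a functional assay on HepG2 cells (Homo sapiens) for antiproliferative activity, read by MTT assay, with a stated time of 48 h (on this read-out lower numbers stand for stronger inhibition and higher numbers for weaker inhibition), compound 1 gives the lowest number of the three. The step to compound 2 is small, a 1.8-fold higher number from compound 1 to compound 2 (0.24 log units; within the scatter), while compound 3 stands far higher, though it differs from compound 1 in more than one place, so its values alone cannot be tied to a single change.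

Compound 4 `COc1cc2oc(-c3ccccc3)cc(=O)c2c(O)c1OCCCCN1CCCCC1` differs from compound 1 by hydrogen in place of phenyl on a saturated chain carbon bound to an oxygen on an aromatic ring. Going by the values given here, no measured step alters this group on its own, so there is no direct precedent. Among the compounds with values here, the only measured step, from compound 1 to compound 2, concerns the amine end and was within the scatter. A modest weakening is therefore expected, a 2.1-fold higher number from compound 1 to compound 4 (0.32 log units; beyond the scatter), with compound 4 estimated at 5000 nM, between 1500 nM and 20000 nM.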

Compound 4, half-maximal inhibitory concentration: 21000 nM
Compound 4: the middle estimate sits 4.2-fold (0.62 log units) below what was measured, outside the stated range (above it).
By their numbers in this assay, from the lowest: compounds 1 and 2 (each within the scatter of the next); then compound 4; then compound 3.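

Measured in this assay the change from benzyloxy to methoxy gives an 8.8-fold higher number from compound 1 to compound 4 (0.94 log units; beyond the scatter) and so goes beyond the scatter. Going by these compounds alone, this is the first sign that the phenyl on this saturated chain carbon counts for growth inhibition, whereas the one earlier step, at the amine end, stayed within the scatter. Nothing available here explains the loss. Still open, from the compounds shown here alone, is how much of the loss belongs to the phenyl ring itself. An ethoxy or cyclohexylmethoxy group in the same place would help separate the ring from the carbon chain that carries it.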